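The compounds below may be only part of what the source reports. "The series", "measured", "known", "first", "only" and "open" are said of these compounds alone.

Working notes on the series.

Compound 1 `CCN(CC)CCCNC(=O)c1ccc(C(CC)(CC)c2ccc(OCC(=O)C(C)(C)C)c(C)c2)n1CC` is the reference. In a functional assay on HepG2 cells (Homo sapiens), read by MTT assay, with a stated time of 48 h (on this read-out higher numbers stand for weaker inhibition and lower numbers for stronger inhibition), compound 1 gives 180 nM. Compound 2 `CCN(CC)CCCNC(=O)c1ccc(C(CC)(CC)c2ccc(OCC(O)C(C)(C)C)c(C)c2)n1CC` differs from compound 1 only by 1-hydroxy-2,2-dimethylpropyl in place of (tert-butyl)carbonyl on a saturated chain carbon bound to an oxygen on an aromatic ring. In this assay compound 2 gives 1100 nM, a step of a 6.1-fold higher number from compound 1 to compound 2 (0.79 log units; beyond the scatter).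

Compound 3 `CC[C@@H](C)[C@H](NC(=O)c1ccc(C(CC)(CC)c2ccc(OCC(=O)C(C)(C)C)c(C)c2)n1CC)C(=O)O` carries a different amide substituent; the core difference from compound 1 is 1-carboxy-2-methylbutyl in place of 3-(diethylamino)propyl on an amide-type nitrogen. In this assay compound 3 gives 247 nM, and the step is a 1.4-fold higher number from compound 1 to compound 3 (0.14 log units; within the scatter), so the two cores sit close together on this read-out.

Compound 4 `CC[C@@H](C)[C@H](NC(=O)c1ccc(C(CC)(CC)c2ccc(OCC(O)C(C)(C)C)c(C)c2)n1CC)C(=O)O` is the unmeasured member. Relative to compound 3 it shows (1-hydroxy-2,2-dimethylpropyl in place of (tert-butyl)carbonyl on a saturated chain carbon bound to an oxygen on an aromatic ring). The place of the change reads the same, word for word, as in the pair from compound 1 to compound 2, so this is the same change, seen once so far among the compounds here, and on two cores that themselves differ little in this assay.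

The expected step is a 5.7-fold higher number from compound 3 to compound 4 (0.75 log units; beyond the scatter), set to match a 6.1-fold higher number from compound 1 to compound 2 (0.79 log units; beyond the scatter) in size, resting on that single precedent. Compound 4 is accordingly estimated at 1400 nM in this assay, within a range from 600 nM to 3500 nM.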

Compound 4, half-maximal inhibitory concentration: 127 nM
The estimate for compound 4 lay 11-fold (1.04 log units) above the measured number; measured number below the stated range.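

In this assay, replacing (tert-butyl)carbonyl with 1-hydroxy-2,2-dimethylpropyl does not keep its size from one core to the other, giving a 6.1-fold higher number from compound 1 to compound 2 (0.79 log units; beyond the scatter) on the first core but only a 1.9-fold lower number from compound 3 to compound 4 (0.29 log units; within the scatter) on the second: the same change on two cores in this assay, a 6.1-fold higher number (0.79 log units; beyond the scatter) from compound 1 to compound 2 and a 1.9-fold lower number (0.29 log units; within the scatter) from compound 3 to compound 4, 12-fold (1.08 log units) apart, beyond the scatter of two such steps.

Read the other way round, 1-carboxy-2-methylbutyl in place of 3-(diethylamino)propyl gives a 1.4-fold higher number from compound 1 to compound 3 (0.14 log units; within the scatter) with the ketone but an 8.7-fold lower number from compound 2 to compound 4 (0.94 log units; beyond the scatter) with the alcohol: the same change on two cores in this assay, a 1.4-fold higher number (0.14 log units; within the scatter) from compound 1 to compound 3 and an 8.7-fold lower number (0.94 log units; beyond the scatter) from compound 2 to compound 4, 12-fold (1.08 log units) apart, beyond the scatter of two such steps.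

So in these four compounds the two changes are not independent, and a step measured on the core of compound 1 cannot be carried over to the core of compound 3, though a single pair on each core does not show how the two places are linked or whether this holds more widely.

Still open, as far as these compounds go, is whether the difference between the cores follows the carboxylic acid or the branched chain of 1-carboxy-2-methylbutyl. A methyl ester or a carboxylic acid on a shorter, unbranched chain, each paired as ketone and alcohol, would separate the two.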